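The compounds below may be only part of what the source reports. "The series", "measured", "known", "first", "only" and "open" are said of these compounds alone.

Compound 1 `O=C(O)/C(O)=C/C(=O)c1cn(Cc2ccc(C(F)(F)F)cc2)c2ccc(Cl)cc12` gives 23000 nM in an ADME assay on MT4 cells (Homo sapiens) for cytotoxicity, read by MTT assay; on this read-out higher numbers stand for lower toxicity in this test and lower numbers for higher toxicity in this test. Compound 2 `O=C(O)/C(O)=C/C(=O)c1cn(Cc2ccc(C(F)(F)F)cc2)c2ccc(F)cc12` differs from it by fluoro in place of chloro on an aromatic carbon and gives 15000 nM, a step recorded as a 1.5-fold lower number from compound 1 to compound 2 (0.19 log units; within the scatter). Compound 3 `Cc1cc(C)c(Cn2cc(C(=O)C3=C(O)C(=O)OC3)c3cc(Cl)ccc32)c(C)c1` rests on a core whose difference from the core of compound 1 is not broken down here; in this assay compound 3 gives 40500 nM. Compound 4 `Cc1cc(C)c(Cn2cc(C(=O)C3=C(O)C(=O)OC3)c3cc(F)ccc32)c(C)c1` carries the same change relative to compound 3, namely (fluoro in place of chloro on an aromatic carbon), at a place described in identical words to the earlier one. Because the earlier step of a 1.5-fold lower number from compound 1 to compound 2 (0.19 log units; within the scatter) stayed within the scatter, a comparably small step is expected in this assay, namely a 1.4-fold lower number from compound 3 to compound 4 (0.13 log units; within the scatter). Compound 4 is therefore estimated at 30000 nM. Compound 4 is expected to fall between 15000 nM and 60000 nM.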

Compound 4, half-maximal cytotoxic concentration: 107000 nM
The estimate for compound 4 lay 3.6-fold (0.55 log units) below the measured number, outside the stated range (above it).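

In this assay, fluoro in place of chloro on an aromatic carbon gave a 2.6-fold higher number from compound 3 to compound 4 (0.42 log units; beyond the scatter), so the change did not carry over unaltered from one core to the other: the same change on two cores in this assay, a 1.5-fold lower number (0.19 log units; within the scatter) from compound 1 to compound 2 and a 2.6-fold higher number (0.42 log units; beyond the scatter) from compound 3 to compound 4, 4.1-fold (0.61 log units) apart, beyond the scatter of two such steps. This shows that, in this series, the step seen on the core of compound 1 cannot simply be transferred to the core of compound 3. Going by these compounds alone, it does not show why the two cores part ways, and with only two pairs it says nothing about how the change would behave on any further core. The compounds shown leave open how a nitrile or an amine on the same aromatic carbon would compare with fluoro and chloro. They also leave open which part of the difference between the two cores goes with the gap between the steps.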